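This account rests on a few compounds, and the source may have more. Where it says the series, first, only, none or still open, it means among the compounds named here.

Measured compounds in a functional assay on HL-60 cells (Homo sapiens) for cytotoxicity, read by MTT assay, with a stated time of 48 h; on this read-out higher numbers stand for weaker inhibition and lower numbers for stronger inhibition:
compound 1 `COc1ccc(-c2c[nH]c(=O)n2-c2cc(OC)c(OC)c(OC)c2)cc1OC`, 38800 nM
compound 2 `COc1ccc(-c2c[nH]c(=O)n2-c2cc(OC)c(OC)c(OC)c2)cc1N`, 10300 nM
compound 3 `COc1ccc(-c2cn(C(=O)Nc3cc(OC)c(OC)c(OC)c3)c(=O)n2-c2cc(OC)c(OC)c(OC)c2)cc1OC`, 6500 nM

Compound 1 and compound 2 share a core and differ only by amino in place of methoxy on an aromatic carbon; this change gave a 3.8-fold lower number from compound 1 to compound 2 (0.58 log units; beyond the scatter). Compound 3 carries a further substituted core; the difference between the cores of compound 1 and compound 3 is not broken down here. Compound 3 and compound 2 lie within the usual scatter of each other, while the number of compound 3 is lower than that of compound 1.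

Compound 4 `COc1ccc(-c2cn(C(=O)Nc3cc(OC)c(OC)c(OC)c3)c(=O)n2-c2cc(OC)c(OC)c(OC)c2)cc1N` is not yet measured. It relates to compound 3 exactly as compound 2 relates to compound 1: the change is amino in place of methoxy on an aromatic carbon, the same change at the same place. On the core of compound 1 this change gave a modest step beyond the scatter, and the only grounds for expecting anything of compound 4 in this assay are that single step of compound 1 to compound 2 together with the value of compound 3. On that basis the expected step is a 3.0-fold lower number from compound 3 to compound 4 (0.47 log units; beyond the scatter). Compound 4 is estimated at 2200 nM, with a range of 1000 nM to 5000 nM.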

Compound 4, half-maximal inhibitory concentration: 3100 nM
Estimate against measurement, compound 4: 1.4-fold (0.15 log units) below; the measured number falls inside the stated range.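

In this assay, the change from 3,4-dimethoxyphenyl to 3-amino-4-methoxyphenyl also lowers the number on the further substituted core, giving a 2.1-fold lower number from compound 3 to compound 4 (0.32 log units; beyond the scatter), so the direction seen on the core of compound 1 holds on the core of compound 3. The two steps cannot be told apart in size: the same change on two cores in this assay, a 3.8-fold lower number (0.58 log units; beyond the scatter) from compound 1 to compound 2 and a 2.1-fold lower number (0.32 log units; beyond the scatter) from compound 3 to compound 4, 1.8-fold (0.25 log units) apart, within the scatter of two such steps. This shows that the change carried over between these two cores in this one assay, with a single pair on each core; it does not show that the extra substitution on the core of compound 3 alters the step, nor that the change would carry over to any other core or read-out.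

The compounds shown leave open whether a hydroxyl, an acetamide or a dimethylamino group at the same place would follow the amino group. They also leave open whether a smaller acetyl or methyl group, in place of the substituent that sets the core of compound 3 apart, would keep the step.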